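Working notes on the substituent on the ring nitrogen

The compounds below may be only part of what the source reports. "The series", "measured", "known", "first", "only" and "open" are said of these compounds alone.

Measured so far in a functional assay on HCC1806 cells (Homo sapiens) for inhibition, read by sulforhodamine B assay, tested at 10 uM; a lower number here means less inhibition, a higher number more inhibition at the concentration tested (going by the name of the read-out):
compound 1 `COC(=O)CC(=O)N1N=C(c2ccc(N3CCN(C)CC3)cc2)CC1c1ccc(N(C)C)cc1`: -8.3%
compound 2 `CN1CCN(c2ccc(C3=NN(C(=O)c4ccc(F)cc4)C(c4ccc(N(C)C)cc4)C3)cc2)CC1`: 31.8%
compound 3 `CN(C)c1ccc(C2CC(c3ccc(-n4cncn4)cc3)=NN2C(=O)c2ccc(F)cc2)cc1`: 15.6%

Compound 3 stands second highest of the three numbers; compound 2 lies above it by a number 16.2 percentage points lower from compound 2 to compound 3 (beyond the scatter), and compound 1 sits lowest. Compound 4 `CN(C)c1ccc(C2CC(c3ccc(-n4cncn4)cc3)=NN2S(=O)(=O)c2ccc(C#N)cc2)cc1` is not yet measured; it differs from compound 3 by (4-cyanophenyl)sulfonyl in place of (4-fluorophenyl)carbonyl on an amine nitrogen in a ring. Among the measured compounds shown here, the only measured step at this position is a number 40.1 percentage points higher from compound 1 to compound 2 (beyond the scatter), a large step, showing that this substituent can move the read-out strongly. For the measured compounds named here, no measured pair shows a sulfonyl or a nitrile on the aryl ring, so the direction is open. A step of a number 2.4 percentage points higher from compound 3 to compound 4 (within the scatter) is expected, within the scatter, with a wide range. Compound 4 is expected to give 18%, between -10% and 45%.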

Compound 4, a percentage reported as inhibition, at one concentration (the size of the read-out at that concentration, not a potency): 33.1%
Compound 4: the middle estimate sits 15.1 percentage points below what was measured; measured number inside the range.
By their numbers in this assay, from the lowest: compound 1; then compound 3; then compounds 2 and 4 (each within the scatter of the next).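

In this assay, (4-cyanophenyl)sulfonyl in place of (4-fluorophenyl)carbonyl gives a number 17.5 percentage points higher from compound 3 to compound 4 (beyond the scatter) on the triazole-bearing compounds. The position therefore accepts a sulfonyl as well as a carbonyl attachment, and the read-out still moves with the 4-(1H-1,2,4-triazol-1-yl)phenyl group held fixed. No measurement at hand accounts for the step. The step joins two changes, the sulfonyl and the nitrile, and the compounds shown do not separate them. Also open, on these data alone, is how a (4-fluorophenyl)sulfonyl group, or a carboxylic acid in place of the nitrile, would read.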